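A few compounds are considered here, and "the series" means these few. Any claim that something is new, unique, unknown or untested is made for them only; others in the source may bear on it.

Compound 1 `Cc1cc(-c2ccc3[nH]ccc3c2)cn2c(CSCCc3ccccc3)cnc12` gives >= 20 ug/mL in an ADME assay on HEL cells (Homo sapiens) for cytotoxicity, with a stated time of 3 days; on this read-out higher numbers stand for lower toxicity in this test and lower numbers for higher toxicity in this test; this is a limit of the assay (the limit of >= 20 ug/mL in this assay, at which 1 of the 3 values shown sits). Compound 2 `Cc1cc(N2CCCC2)cn2c(CSCCc3ccccc3)cnc12` gives 20 ug/mL in this assay. Compound 3 `Cc1cc(-n2ccnc2)cn2c(CSCCc3ccccc3)cnc12` gives 100 ug/mL in this assay.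

Compound 3 holds the highest of the two readable numbers; its nearest neighbour is compound 2, with a 5.0-fold higher number from compound 2 to compound 3 (0.70 log units; beyond the scatter). Compound 4 `Cc1cc(-n2ccc3ccccc32)cn2c(CSCCc3ccccc3)cnc12` differs from compound 3 by 1H-indol-1-yl in place of 1H-imidazol-1-yl on an aromatic carbon. Going by the values given here, two measured steps bear on this change: a step that the limit leaves unreadable from compound 1 to compound 3, which the limit leaves unreadable, and a 5.0-fold higher number from compound 2 to compound 3 (0.70 log units; beyond the scatter), a modest step. Since the entering 1H-indol-1-yl is closer in size to the groups of compound 1 and compound 2 than to 1H-imidazol-1-yl, a modest step downward in this assay is expected for compound 4, estimated as a 2.9-fold lower number from compound 3 to compound 4 (0.46 log units; beyond the scatter). Compound 4 is therefore expected to give about 35 ug/mL, within 10 ug/mL to 100 ug/mL.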

Compound 4, minimum cytotoxic concentration: > 20 ug/mL
Compound 4: only a limit was reported (the forecaster's own chance of this, stated with the estimate: 35%); the middle value is on the limit's open side.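

Compound 4 carries only a limit of the assay: the limit of > 20 ug/mL in this assay, at which 1 of the 4 values shown sits. Set against pyrrolidin-1-yl on this aromatic carbon, 1H-indol-1-yl gives a number no lower from compound 2 to compound 4 (the limit leaves the size open), so the one direction that can be read is that this fused group does not lower the number. The steps from compound 3 and from compound 1 to compound 4 cannot be read. The compounds shown leave open where compound 4 truly stands relative to compound 3, and how a morpholin-4-yl group or a carboxylic acid on this carbon would read in this assay.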